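Lengthening the ester chain in a quinazoline series

The source may report more compounds than this note shows. Statements on the series, on what has been measured and on what is new or still open speak of the compounds shown alone.

The three measured compounds share one core and differ only in the length of the alkyl ester chain. In a functional assay on A549 cells (Homo sapiens) for cytotoxicity, read by MTT assay, with a stated time of 24 h, tested at 60 uM (a lower number here means a stronger effect, a higher number a weaker effect of the compound at the concentration tested), compound 1 `CCCCCCCCOC(=O)CCC(=O)N1CCN(CCCOc2cc3c(Nc4ccc(F)c(Cl)c4)ncnc3cc2OC)CC1` gives 26%, compound 2 `CCCCCCCCCOC(=O)CCC(=O)N1CCN(CCCOc2cc3c(Nc4ccc(F)c(Cl)c4)ncnc3cc2OC)CC1` gives 10.3%, and compound 3 `CCCCCCCCCCCOC(=O)CCC(=O)N1CCN(CCCOc2cc3c(Nc4ccc(F)c(Cl)c4)ncnc3cc2OC)CC1` gives 3.9%. Compound 3 holds the lowest of the three numbers; its gap to compound 2 lies within the scatter, while its gap to compound 1 lies beyond it.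

Compound 4 `CCCCCCCCCCCCCCCCOC(=O)CCC(=O)N1CCN(CCCOc2cc3c(Nc4ccc(F)c(Cl)c4)ncnc3cc2OC)CC1` carries the change (pentyl in place of hydrogen on a saturated chain carbon, ten or more bonds along the chain from an oxygen next to a carbonyl group). Among the measured compounds shown here, the steps that bear on it all extend the same chain: a number 15.7 percentage points lower from compound 1 to compound 2 (beyond the scatter), a number 22.1 percentage points lower from compound 1 to compound 3 (beyond the scatter) and a number 6.4 percentage points lower from compound 2 to compound 3 (within the scatter). The first two were modest and beyond the scatter, the third within it, and the number is already close to the floor of this assay. A further extension is therefore expected to bring at most a small change, downward if any. The step is expected to be a number 0.9 percentage points lower from compound 3 to compound 4 (within the scatter). In this assay compound 4 is expected to give 3%, with a range from 0% to 14%.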

Compound 4, a percentage reported as activity, at one concentration (the size of the read-out at that concentration, not a potency): 80%
The estimate for compound 4 lay 77 percentage points below the measured number; the whole stated range lies below it.
By their numbers in this assay, from the lowest: compounds 3 and 2 (each within the scatter of the next); then compound 1; then compound 4.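

Extending the chain at this position does not keep lowering the number in this assay: adding pentyl reverses the direction, with a number 76.1 percentage points higher from compound 3 to compound 4 (beyond the scatter), and compound 4 also stands apart from the shorter esters, with a number 69.7 percentage points higher from compound 2 to compound 4 (beyond the scatter) and a number 54 percentage points higher from compound 1 to compound 4 (beyond the scatter). The downward run from compound 1 to compound 3 therefore holds only over that part of the series, and compound 4 goes against it, so chain length here has no single direction of effect. Nothing measured bears on the reason for this reversal.

The compounds shown leave open where the number turns upward, as a tridecyl ester would fall in the gap between the chains of compound 3 and compound 4. They also leave open whether a terminal carboxylic acid or amine on the long chain would change the outcome.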